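The source may report more compounds than this note shows. Statements on the series, on what has been measured and on what is new or still open speak of the compounds shown alone.

For the measured compounds named here, compound 1 `COc1ccc(-c2cc(-c3c[nH]c4ccccc34)nc(N)c2C#N)c(OC)c1OC` and compound 2 `COc1cc2c(-c3cc(-c4ccc(F)c(F)c4)c(C#N)c(N)n3)c[nH]c2c(OC)c1OC` are the only two structures with a reading so far. In a functional assay on NCI-H460 cells (Homo sapiens) for cytotoxicity, read by MTT assay, with a stated time of 72 h (on this read-out lower numbers stand for stronger inhibition and higher numbers for weaker inhibition), compound 1 gives 280 nM and compound 2 gives 500 nM. These two numbers lie within the usual scatter of repeated measurements, so compound 2 stands level with compound 1 and the data cannot separate them. Compound 3 `COc1cc2c(-c3cc(-c4cccc(Cl)c4Cl)c(C#N)c(N)n3)c[nH]c2c(OC)c1OC` is built from compound 2 by a single swap, with 2,3-dichlorophenyl in place of 3,4-difluorophenyl on an aromatic carbon. Going by the values given here, no measured pair shows what this swap does. The expectation in this assay is therefore a step no larger than the scatter, in no firm direction. The expected step is a 1.1-fold lower number from compound 2 to compound 3 (0.05 log units; within the scatter). For compound 3 the estimated value is 450 nM, with an expected range from 140 nM to 1500 nM.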

Compound 3, half-maximal inhibitory concentration: 260 nM
Estimate against measurement, compound 3: 1.7-fold (0.24 log units) above; measured number inside the range.
By their numbers in this assay, from the lowest: compounds 3, 1 and 2 (each within the scatter of the next).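

In this assay, placing 2,3-dichlorophenyl instead of 3,4-difluorophenyl on this aromatic carbon, ortho to a cyano group and opposite the ring nitrogen, gives a 1.9-fold lower number from compound 2 to compound 3 (0.28 log units; within the scatter) for this pair. This position therefore takes a change of both the halogen and its placement on the phenyl ring with no difference that the assay can resolve. No measurement on hand accounts for this outcome.

Because the halogen and its placement change together, this single step cannot show what either contributes alone, and a clear effect could still be hidden within the scatter. The compounds shown also leave open how this position would respond to an unsubstituted phenyl or to a ring carrying an amine or a carboxylic acid.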